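This account rests on a few compounds, and the source may have more. Where it says the series, first, only, none or still open, it means among the compounds named here.

Three compounds have been tested in a functional assay on SR cells (Homo sapiens) for inhibition, read by sulforhodamine B assay, with a stated time of 48 h, tested at 10 uM; on this read-out lower numbers stand for less inhibition and higher numbers for more inhibition at the one concentration tested (going by the name of the read-out):
Compound 1 `c1ccc(-c2cn3ccnc3c(-c3ccc4ncn(C5CCCCC5)c4c3)n2)cc1` gives 59.8%.
Compound 2 `c1cn2cc(-c3ccsc3)nc(-c3ccc4ncn(C5CCCCC5)c4c3)c2n1` gives 14.3%.
Compound 3 `CC(=O)c1ccc(-c2cn3ccnc3c(-c3ccc4ncn(C5CCCCC5)c4c3)n2)cc1` gives 23.6%.

Compound 3 stands second highest of these three numbers; its gap to compound 2 lies within the scatter, while compound 1 sits well above it. Compound 4 `COc1ccccc1-c1cn2ccnc2c(-c2ccc3ncn(C4CCCCC4)c3c2)n1` is the next compound, and its change from compound 3 is 2-methoxyphenyl in place of 4-acetylphenyl on an aromatic carbon. Among the compounds with values here, two measured steps bear on this. a number 36.2 percentage points lower from compound 1 to compound 3 (beyond the scatter) shows that acetyl in place of hydrogen on an aromatic carbon cost much of the effect, so removing it could restore some. Yet a number 45.5 percentage points lower from compound 1 to compound 2 (beyond the scatter) shows that another alteration of the phenyl also cost much. Since compound 4 keeps a phenyl that carries a substituent, only a modest rise is expected, a number 14.4 percentage points higher from compound 3 to compound 4 (beyond the scatter). Compound 4 is estimated at 38%, within a range of 15% to 62%.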

Compound 4, a percentage reported as inhibition, at one concentration (the size of the read-out at that concentration, not a potency): 26.3%
Compound 4: the middle estimate sits 11.7 percentage points above what was measured; the range from low to high includes it.
By their numbers in this assay, from the lowest: compounds 2, 3 and 4 (each within the scatter of the next, the first and the last beyond it); then compound 1.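

In this assay, the step of a number 2.7 percentage points higher from compound 3 to compound 4 (within the scatter) means that 2-methoxyphenyl and 4-acetylphenyl at this position cannot be told apart. Methoxy on the phenyl still falls short of the unsubstituted ring, with a number 33.5 percentage points lower from compound 1 to compound 4 (beyond the scatter), yet 2-methoxyphenyl improves on thiophen-3-yl, with a number 12 percentage points higher from compound 2 to compound 4 (beyond the scatter), so acetyl and methoxy, each at its own place on the phenyl, both stay well short of compound 1. No measurement shown explains these differences.

On these data alone, it remains open whether any substituent on this phenyl can keep the level of compound 1. An amine or a carboxylic acid there would test this.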